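The compounds below may be only part of what the source reports. "The series", "measured", "known", "first", "only" and "open" are said of these compounds alone.

Measured compounds in a functional assay on Hep cells (Homo sapiens) for cytotoxicity, read by sulforhodamine B assay, with a stated time of 48 h; a higher number here means a weaker inhibitor, a lower number a stronger inhibitor:
compound 1, `O=C(c1cccnc1)c1cc(Cl)cc(Cl)c1O`: 27000 nM
compound 2, `O=C(c1cccnc1)c1cc(Cl)ccc1O`: 27000 nM
compound 3, `C=CCOc1ccc(Cl)cc1C(=O)c1cccnc1`: this value is a limit of this assay, > 100000 nM

Compound 1 and compound 2 differ in one place, (hydrogen in place of chloro on an aromatic carbon). That step, no change at the digits printed from compound 1 to compound 2 (within the scatter), leaves the read-out where it was. From compound 2 to compound 3 the change is the allyl group on the phenolic oxygen, and there the step is an at least 3.7-fold higher number from compound 2 to compound 3 (0.56 log units; beyond the scatter); the size is only a lower bound, since compound 3 sits at the limit of > 100000 nM in this assay, at which 1 of the 3 values shown sits.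

Compound 4, `C=CCOc1ccccc1C(=O)c1cccnc1`, is not yet measured in this assay. It differs from compound 3 by hydrogen in place of chloro on an aromatic carbon. Going by the values given here, this is the same kind of change as the one from compound 1 to compound 2, but not the same: around the place it differs in that the first change sits ortho to a hydroxy group and meta to a chloro group, whereas in compound 3 the carbon sits para to an allyloxy group. How the core of compound 3 differs from the core of compound 1 is not broken down here.

Among the compounds with values here, the one measured instance of removing this chloro group, from compound 1 to compound 2, shows no change within the scatter. On that basis the step from compound 3 to compound 4 is expected to be a number no higher from compound 3 to compound 4 (the limit leaves the size open), and compound 4 is estimated at 100000 nM, most likely again reported only as a limit.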

Compound 4, half-maximal inhibitory concentration: > 100000 nM
Compound 4 ended at the assay's limit (the forecaster's own chance of this, stated with the estimate: 80%); the middle value sits exactly at the limit.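

In this assay compound 4 gives > 100000 nM, which is a limit of the assay. Going by these compounds alone, compound 3 also stands at a limit, so no step between compound 3 and compound 4 can be read: the limit of > 100000 nM in this assay, at which 2 of the 4 values shown sit. The compounds shown leave open whether hydrogen in place of chloro changes the read-out at all when an allyloxy group is present.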